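Extending the ether chain: an expected small shift

The source may hold more compounds than are shown below. What is called first, only, known or untested is meant among the compounds shown, and "the series" means these compounds.

Compound 1 `COc1cccc(-n2cc(C(=O)NCCCCN3CCc4cc(OC)c(OC)cc4C3)nn2)c1`: 20200 nM
Compound 2 `COc1cccc(-n2cc(C(=O)NCCN3CCc4cc(OC)c(OC)cc4C3)nn2)c1`: 76700 nM
Compound 3 `COc1cc2c(cc1OC)CN(CCCCNC(=O)c1ccc(-c3cn(CCOCCF)nn3)cc1)CC2`: 14700 nM

All three compounds were tested in an assay on membranes from brain for displacement of a labelled ligand from Sigma non-opioid intracellular receptor 1 (Cavia porcellus), read by scintillation counting, with a stated time of 90 min; on this read-out higher numbers stand for weaker inhibition and lower numbers for stronger inhibition. Compound 3 sits within the usual scatter of compound 1, so the two cannot be told apart on these numbers. Against compound 2 the gap is larger: compound 2 has the higher number, and that difference lies beyond the scatter.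

Compound 4 `COc1cc2c(cc1OC)CN(CCCCNC(=O)c1ccc(-c3cn(CCOCCOCCF)nn3)cc1)CC2` has not yet been measured. It differs from compound 3 in one place: 2-fluoroethoxy in place of fluoro on a saturated chain carbon, two bonds along the chain from an oxygen on a saturated carbon. This is 2-fluoroethoxy in place of fluoro on a saturated chain carbon, two bonds along the chain from an oxygen on a saturated carbon, so the chain at the far end of the molecule simply grows longer.

Going by the values given here, no measured pair shows what such a chain extension does here. With nothing to point either way, the step is expected to stay within the scatter, so from compound 3 to compound 4 an estimated change of a 1.1-fold lower number from compound 3 to compound 4 (0.02 log units; within the scatter) is anticipated in this assay . Compound 4 is therefore estimated at 14000 nM, with a likely range from 6000 nM to 35000 nM.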

Compound 4, inhibition constant: 16000 nM
Compound 4: the middle estimate sits 1.1-fold (0.06 log units) below what was measured; measured number inside the range.
By their numbers in this assay, from the lowest: compounds 3, 4 and 1 (each within the scatter of the next); then compound 2.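

Replacing fluoro with 2-fluoroethoxy on a saturated chain carbon, two bonds along the chain from an oxygen on a saturated carbon, gives a 1.1-fold higher number from compound 3 to compound 4 (0.04 log units; within the scatter) in this assay. Going by these compounds alone, this is the first pair here that differs in one place, and it shows that the far end of this chain can take the extra carbons and oxygen with no readable change in the binding number. Nothing on hand explains why the number does not move.

From the compounds shown here alone, whether the same holds for a longer chain still, or for a chain that ends in an amine or a carboxylic acid instead of fluorine, stays open. A single pair also cannot show whether this extension would behave the same way on the core of compound 1.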